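This account rests on a few compounds, and the source may have more. Where it says the series, first, only, none or still open, it means among the compounds named here.

For the measured compounds named here, compound 3 `COc1ccc(CNC(=O)/C=C/c2coc3cc(OC)ccc3c2=O)cc1` carries the only number reported in a functional assay (QGY7701 cells, Homo sapiens) for inhibition, read by MTT assay, with a stated time of 48 h; on this read-out higher numbers stand for weaker inhibition and lower numbers for stronger inhibition: compound 3 gives 15700 nM. Compound 1 `COc1ccc2c(=O)c(/C=C/C(=O)Nc3cccc(C)c3)coc2c1` reaches only the assay limit, > 100000 nM. Compound 2 `COc1ccc2c(=O)c(/C=C/C(=O)Nc3cccc(Cl)c3)coc2c1` likewise stops at a limit, > 100000 nM. Compound 4 `COc1ccc2c(=O)c(/C=C/C(=O)Nc3ccc(C)cc3)coc2c1` differs from compound 3 by 4-methylphenyl in place of 4-methoxybenzyl on an amide-type nitrogen. The measured steps that bear on this are those from compound 1 to compound 3, an at least 6.3-fold lower number from compound 1 to compound 3 (0.80 log units; beyond the scatter), and from compound 2 to compound 3, an at least 6.3-fold lower number from compound 2 to compound 3 (0.80 log units; beyond the scatter), both running from an anilide to the benzyl amide; the step that the two limits leave unreadable from compound 1 to compound 2 cannot be read because of the limit of > 100000 nM in this assay, at which 2 of the 3 values shown sit. Returning to an anilide is therefore expected to raise the number, by about a 5.1-fold higher number from compound 3 to compound 4 (0.71 log units; beyond the scatter), and compound 4 is estimated at 80000 nM, between 20000 nM and 300000 nM.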

Compound 4, half-maximal inhibitory concentration: 39300 nM
Beside the measured number, compound 4's estimate is 2.0-fold (0.31 log units) above it; the measured number falls inside the stated range.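

In this assay, compound 4 shows that an anilide on this amide-type nitrogen can give a readable number, though the 4-methoxybenzyl group keeps the lower one, with a 2.5-fold higher number from compound 3 to compound 4 (0.40 log units; beyond the scatter). Among the anilides, 4-methylphenyl outperforms both groups tested so far, with an at least 2.5-fold lower number from compound 1 to compound 4 (0.40 log units; beyond the scatter) and an at least 2.5-fold lower number from compound 2 to compound 4 (0.40 log units; beyond the scatter). Both of these steps give only a minimum size, because each starts from a limit and not a number: the limit of > 100000 nM in this assay, at which 2 of the 4 values shown sit.

Open, going by these compounds, is which part of the 4-methoxybenzyl group carries its advantage. A 4-methylbenzyl or a 4-methoxyphenyl on the same nitrogen would help separate the two parts.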